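The source may hold more compounds than are shown below. What is called first, only, known or untested is meant among the compounds shown, and "the series" means these compounds.

Measured compounds: compound 1 `COc1ccc2[nH]c(-c3ccc[nH]3)c(C3CC(=O)NC3=O)c2c1` with 4000 nM, compound 2 `COc1ccc2[nH]c(-n3cccn3)cc2c1` with 70000 nM, and compound 3 `Cc1ccc2[nH]c(-c3ccc[nH]3)c(C3CC(=O)NC3=O)c2c1` with 4000 nM, all in a functional assay on LoVo cells (Homo sapiens) for cytotoxicity, read by MTT assay, with a stated time of 72 h; a lower number here means a stronger inhibitor, a higher number a weaker inhibitor.

Compound 2 sits highest of the three; its two neighbours are an equal distance away. How the core of compound 2 differs from that of compound 1 is not broken down here. Compound 1 and compound 3 share a core and differ only by methyl in place of methoxy on an aromatic carbon; that step gave no change at the digits printed from compound 1 to compound 3 (within the scatter).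

Compound 4 `Cc1ccc2[nH]c(-n3cccn3)cc2c1` is not yet measured. It differs from compound 2 by methyl in place of methoxy on an aromatic carbon, the same change, at the same kind of place. Because the step of no change at the digits printed from compound 1 to compound 3 (within the scatter) stayed within the scatter, the step from compound 2 to compound 4 is expected to be about as flat, namely no change at the digits printed from compound 2 to compound 4 (within the scatter). On that basis compound 4 is estimated to give 70000 nM in this assay, between 30000 nM and 160000 nM.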

Compound 4, half-maximal inhibitory concentration: 87000 nM
For compound 4 the middle estimate is 1.2-fold (0.09 log units) below the measured one, within the range that was stated.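

In this assay, methyl in place of methoxy gave a 1.2-fold higher number from compound 2 to compound 4 (0.09 log units; within the scatter), so the change was again flat on a second core. The two steps agree, and the change carried across these two cores without a detectable difference: the same change on two cores in this assay, no change at the digits printed (within the scatter) from compound 1 to compound 3 and a 1.2-fold higher number (0.09 log units; within the scatter) from compound 2 to compound 4, 1.2-fold (0.09 log units) apart, within the scatter of two such steps.

Among these compounds, this rests on only two pairs in a single assay, so it does not show that the change would stay flat on any other core, nor does it explain why it was flat here.

The compounds shown leave open whether an amine, a carboxylic acid or a longer alkoxy chain on this aromatic carbon would give a similarly flat step. They also leave open whether a chlorine atom there would do the same on both cores.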